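Swapping the amide-nitrogen substituent in a factor X series

The source may report more compounds than this note shows. Statements on the series, on what has been measured and on what is new or still open speak of the compounds shown alone.

Measured so far:
compound 1, `O=C1[C@@H](NS(=O)(=O)c2ccc(-c3ccon3)s2)CCN1Cc1cc2c[nH]ccc-2n1`, 17%
compound 2, `O=C1[C@@H](NS(=O)(=O)c2nc3cc(Cl)ccc3[nH]2)CCN1CCNc1ccncc1`, 29%

Both numbers come from an assay on isolated protein for inhibition of coagulation factor X (Oryctolagus cuniculus), tested at 1 uM; on this read-out higher numbers stand for more inhibition at the one concentration tested (going by the name of the read-out) and lower numbers for less inhibition. Among the two, compound 2 stands highest, and its gap to compound 1 lies beyond the usual scatter. Compound 3, `O=C1[C@@H](NS(=O)(=O)c2nc3cc(Cl)ccc3[nH]2)CCN1Cc1cc2c[nH]ccc-2n1`, has not yet been tested. It keeps the sulfonamide part of compound 2 and changes only the group on the saturated chain carbon bound to the amide-type nitrogen in the ring: a group of 9 heavy atoms (7 carbon, 2 nitrogen; one five-membered aromatic ring with 1 hetero atom, one six-membered aromatic ring with 1 hetero atom) in place of a group of 8 heavy atoms (6 carbon, 2 nitrogen; one six-membered aromatic ring with 1 hetero atom), on a saturated chain carbon bound to an amide-type nitrogen in a ring. Going by the values given here, the entering group is the one already present in compound 1.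

Among the compounds with values here, no measured pair shows this exact change, so the size of the step is open. Compound 1, which already carries the entering group, gives 17%, which points to a modest downward or flat step. Compound 3 is therefore expected to give about 24%, within 5% to 48%; the expected step is a number 5 percentage points lower from compound 2 to compound 3 (within the scatter).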

Compound 3, a percentage reported as inhibition, at one concentration (the size of the read-out at that concentration, not a potency): 31%
Compound 3: the middle estimate sits 7 percentage points below what was measured; the measured number falls inside the stated range.
By their numbers in this assay, from the lowest: compound 1; then compounds 2 and 3 (each within the scatter of the next).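

Exchanging the ((pyridin-4-yl)amino)methyl group for the group carried by compound 1, on the saturated chain carbon bound to an amide-type nitrogen in a ring, gives in this assay a number 2 percentage points higher from compound 2 to compound 3 (within the scatter) and so, with this sulfonamide part, the two groups cannot be told apart at this position. The sulfonyl sulfur now has a direct comparison too, since 5-chloro-1H-benzimidazol-2-yl in place of 5-(1,2-oxazol-3-yl)thiophen-2-yl gives a number 14 percentage points higher from compound 1 to compound 3 (beyond the scatter) and thus the lower number of compound 1 goes with its sulfonyl group, not with the group on the chain carbon. Nothing at hand explains either step.

Only these two groups can be compared at the chain carbon. From the compounds shown here alone, whether a simple primary amine or a carboxylic acid there would change the inhibition remains open, as does whether the two groups would still match with 5-(1,2-oxazol-3-yl)thiophen-2-yl on the sulfonyl sulfur.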